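Swapping cyano for dimethylamino in compound 2

The source may report more compounds than this note shows. Statements on the series, on what has been measured and on what is new or still open speak of the compounds shown alone.

Measured so far in an ADME assay on THP-1 cells (Homo sapiens) for cytotoxicity, read by resazurin assay, with a stated time of 48 h; on this read-out lower numbers stand for stronger inhibition and higher numbers for weaker inhibition:
Compound 1 `N#Cc1ccc(-c2ccc(Cn3cccc(O)c3=O)cc2)cc1` gives > 10 ug/mL
Compound 2 `N#Cc1ccc(-c2ccc(Cn3cccc(O)c3=S)cc2)cc1` gives > 10 ug/mL
Compound 3 `N#Cc1ccccc1-c1ccc(Cn2cccc(O)c2=O)cc1` gives > 10 ug/mL

Compound 2 gives > 10 ug/mL here, which is a limit and not a number. Across the three compounds, the limit of > 10 ug/mL in this assay, at which 3 of the 3 values shown sit, is all that is known. For the measured compounds named here, compound 4 `CN(C)c1ccc(-c2ccc(Cn3cccc(O)c3=S)cc2)cc1` keeps the rest of compound 2 but carries dimethylamino in place of cyano on an aromatic carbon, para to a large group dimethylamino in place of cyano on an aromatic carbon as the one change. Going by the values given here, no measured pair shows this change, so in this assay no step in either direction beyond the scatter is expected, with compound 2 at > 10 ug/mL as the only anchor. The expected step is a step that the limit leaves unreadable from compound 2 to compound 4 and stays within the scatter. For compound 4 the estimated value is 12 ug/mL with 5 ug/mL to 30 ug/mL as its expected range.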

Compound 4, half-maximal inhibitory concentration: > 10 ug/mL
Compound 4: only a limit was reported (the forecaster's own chance of this, stated with the estimate: 70%); the middle value lies beyond the limit too.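

Compound 2 and compound 4 each give only a limit, so no step can be read between them: the limit of > 10 ug/mL in this assay, at which 4 of the 4 values shown sit.

The compounds shown leave open whether dimethylamino in place of cyano changes the result in this assay at all.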